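The compounds below may be only part of what the source reports. "The series", "measured", "known", "first", "only" and "open" are said of these compounds alone.

Three compounds share one core in an assay for inhibition of Maternal embryonic leucine zipper kinase (Homo sapiens), read by ADP-Glo, with a stated time of 0.5 h; a higher number here means a weaker inhibitor, a lower number a stronger inhibitor. Compound 1 `COc1ccc(C(=O)c2sc(NC(C)C)c(C#N)c2N)cc1` gives 4130 nM. Compound 2 `CC(C)Nc1sc(C(=O)c2ccc(I)s2)c(N)c1C#N` gives 112 nM. Compound 3 `CC(C)N(C)c1sc(C(=O)c2ccc(Cl)s2)c(N)c1C#N` gives 1420 nM, the second highest of the three numbers: compound 1 lies above it beyond the scatter, and compound 2 lies well below it beyond the scatter.

The step to compound 4 `N#Cc1c(Nc2ccccc2F)sc(C(=O)c2ccc(Cl)s2)c1N` is (2-fluorophenyl)amino in place of isopropyl(methyl)amino on an aromatic carbon. Within the data shown here, no pair differing in only one place has been measured, so the size of this step is open. Because compound 3 gives 1420 nM while compound 2, which also carries a hydrogen on its ring nitrogen, gives 112 nM, a move to a lower number is expected from compound 3 to compound 4, a 4.1-fold lower number from compound 3 to compound 4 (0.61 log units; beyond the scatter). Compound 4 is estimated at 350 nM, in the range 70 nM to 1700 nM.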

Compound 4, half-maximal inhibitory concentration: 707 nM
Compound 4: the middle estimate sits 2.0-fold (0.31 log units) below what was measured, and the stated range covers the measured number.
By their numbers in this assay, from the lowest: compound 2; then compounds 4 and 3 (each within the scatter of the next); then compound 1.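

On the aromatic carbon next to the ring sulfur, (2-fluorophenyl)amino in place of isopropyl(methyl)amino gives a 2.0-fold lower number from compound 3 to compound 4 (0.30 log units; within the scatter). This position therefore accepts an entering group with a six-membered aromatic ring and a hydrogen-bond donor, with no change in this assay beyond the scatter. Nothing available explains this result.

Still open, as far as these compounds go, is what the fluorine contributes, which a plain phenylamino group at this carbon would test. A morpholine or an unsubstituted amino group there could show whether any replacement moves the number beyond the scatter.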